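The source may hold more compounds than are shown below. What is called first, only, known or untested is meant among the compounds shown, and "the series" means these compounds.

Compound 1 `CC(C)(C)C1=CC(=O)C=C(NCCC(=O)O)C1=O`: 94100 nM
Compound 2 `CC(C)(C)C1=CC(=O)C=C(NCC(=O)O)C1=O`: 171000 nM

In a functional assay on MDA-MB-453 cells (Homo sapiens) for cytotoxicity, read by MTT assay, with a stated time of 72 h (on this read-out higher numbers stand for weaker inhibition and lower numbers for stronger inhibition), compound 2 gives 171000 nM, a number within the scatter of compound 1 at 94100 nM. The next case is compound 3 `CC(C)(C)C1=CC(=O)C=CC1=O`, which loses the whole side chain of compound 2: hydrogen in place of (carboxymethyl)amino on a double-bonded ring carbon. In words, this is hydrogen in place of (carboxymethyl)amino on a double-bonded ring carbon. Going by the values given here, only one measured step bears on this change: a 1.8-fold higher number from compound 1 to compound 2 (0.26 log units; within the scatter). That step swaps carboxymethyl for carboxy and leaves the amine nitrogen in place, so the data offer no direct guide to removing the entire group. Compound 2, at 171000 nM, leaves more room downward than upward, so a move to a lower number is expected, though with wide uncertainty. The expected step is a 5.7-fold lower number from compound 2 to compound 3 (0.76 log units; beyond the scatter). For compound 3, the estimate is 30000 nM, with an expected range from 6000 nM to 120000 nM.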

Compound 3, half-maximal inhibitory concentration: 56800 nM
Compound 3: middle estimate off by 1.9-fold (0.28 log units), on the low side; measured number inside the range.
By their numbers in this assay, from the lowest: compounds 3, 1 and 2 (each within the scatter of the next, the first and the last beyond it).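

In this assay taking off the whole (carboxymethyl)amino group and leaving hydrogen gives a 3.0-fold lower number from compound 2 to compound 3 (0.48 log units; beyond the scatter) and so shows that this side chain is not needed for the cytotoxicity seen here: the core with its tert-butyl group gives a measurable effect without it. Putting hydrogen in place of (2-carboxyethyl)amino at the same ring carbon gives a 1.7-fold lower number from compound 1 to compound 3 (0.22 log units; within the scatter) and stays within the scatter, so of the two side chains only (carboxymethyl)amino separates measurably from hydrogen. No measurement given here explains these differences.

Still open, from the compounds shown here alone, is how a plain amine at this ring carbon would read, which would show what the nitrogen does without the carboxylic acid. A methyl ester in place of that acid would pose the same question from the other end of the chain.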